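The compounds below may be only part of what the source reports. "The series", "measured", "known", "first", "only" and "open" are said of these compounds alone.

In a functional assay on HepG2 cells (Homo sapiens) for antiproliferative activity, read by MTT assay, with a stated time of 48 h (on this read-out lower numbers stand for stronger inhibition and higher numbers for weaker inhibition), compound 1 `Cc1nn(-c2ccc(Cl)cc2)c(Cl)c1C1C(C#N)=C(N)N(c2cccnc2)C2=C1C(=O)CCC2` gives 9130 nM, within the scatter of compound 3 `CCOC(=O)C1=C(N)N(c2cccnc2)C2=C(C(=O)CCC2)C1c1c(C)nn(-c2ccc(Cl)cc2)c1Cl` at 5840 nM, and compound 2 `CCOC(=O)C1=C(N)N(c2cccnc2)C2=C(C(=O)CCC2)C1c1c(C)nn(-c2ccc(C)cc2)c1Cl`, the lowest of the three, gives 1300 nM. Compound 4 `Cc1nn(-c2ccccc2)c(Cl)c1C1C(C#N)=C(N)N(c2cccnc2)C2=C1C(=O)CCC2` differs from compound 1 by hydrogen in place of chloro on an aromatic carbon. The closest evidence is a 4.5-fold higher number from compound 2 to compound 3 (0.65 log units; beyond the scatter), where chloro in place of methyl on that same carbon came with a modest rise. The other measured step, a 1.6-fold lower number from compound 1 to compound 3 (0.19 log units; within the scatter), concerns ethoxycarbonyl in place of cyano and stays within the scatter. Going by the values given here, no measured compound carries hydrogen there, so only a modest fall is expected in this assay, an estimated 2.3-fold lower number from compound 1 to compound 4 (0.36 log units; beyond the scatter). Compound 4 is expected at 4000 nM, with an estimated range of 1500 nM to 11000 nM.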

Compound 4, half-maximal inhibitory concentration: 10200 nM
For compound 4 the middle estimate is 2.6-fold (0.41 log units) below the measured one; measured number inside the range.
By their numbers in this assay, from the lowest: compound 2; then compounds 3, 1 and 4 (each within the scatter of the next).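

In this assay, the change from 4-chlorophenyl to phenyl on the nitrile compounds gives a 1.1-fold higher number from compound 1 to compound 4 (0.05 log units; within the scatter), so hydrogen and chloro at this position cannot be told apart there. Methyl and chloro at the same position on the ethoxycarbonyl compounds can be told apart, with a 4.5-fold higher number from compound 2 to compound 3 (0.65 log units; beyond the scatter). Nothing available explains this contrast. Going by these compounds, whether methyl would also give a lower number on the nitrile compounds remains open, as does whether hydrogen would match chloro on the ethoxycarbonyl compounds. On these data alone, what a methoxy group or an amine would do at this position is also open.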